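The source may report more compounds than this note shows. Statements on the series, on what has been measured and on what is new or still open speak of the compounds shown alone.

Measured compounds:
compound 1 `O=C(Nc1ccnnc1)c1cc(N2CCCCC2)ccc1OCc1ccccc1` — 25.1 nM
compound 2 `O=C(Nc1ccnnc1)c1cc(N2CCCC2)ccc1OCc1ccccc1` — 20 nM

Both were tested in an assay on Sf9 cells for inhibition of Leucine-rich repeat serine/threonine-protein kinase 2 (Homo sapiens), read by TR-FRET, with stated times of 30 min and 2 h; on this read-out lower numbers stand for stronger inhibition and higher numbers for weaker inhibition. Compound 2 gives the smaller of the two numbers, but the step of a 1.3-fold lower number from compound 1 to compound 2 (0.10 log units; within the scatter) is within the scatter, so the two compounds stand together and nothing separates them. Among the compounds with values here, the only measured step is therefore an exchange of one saturated nitrogen ring for another on the same aromatic carbon, and it produced no change that can be trusted.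

Compound 3 `CN1CCN(c2ccc(OCc3ccccc3)c(C(=O)Nc3ccnnc3)c2)CC1` is the next member: it differs from compound 2 by 4-methylpiperazin-1-yl in place of pyrrolidin-1-yl on an aromatic carbon. The step from compound 1 to compound 2 is the only one that bears on this, since it concerns the same position and the same kind of group; it was small and within the scatter. Within the data shown here, no measured step covers the entry of 4-methylpiperazin-1-yl itself, so the direction of any effect of the added ring nitrogen and methyl cannot be read from the data. The working expectation is accordingly no step beyond the scatter, a 1.5-fold higher number from compound 2 to compound 3 (0.18 log units; within the scatter), with a wide range to allow for the untested group. Compound 3 is estimated at 30 nM, between 8 nM and 120 nM.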

Compound 3, half-maximal inhibitory concentration: 12.6 nM
The estimate for compound 3 lay 2.4-fold (0.38 log units) above the measured number, and the stated range covers the measured number.
By their numbers in this assay, from the lowest: compounds 3, 2 and 1 (each within the scatter of the next).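

In this assay, the position para to a benzyloxy group and meta to a (pyridazin-4-yl)carbamoyl group now carries a third saturated nitrogen ring: 4-methylpiperazin-1-yl in place of pyrrolidin-1-yl gives a 1.6-fold lower number from compound 2 to compound 3 (0.20 log units; within the scatter), and the same group in place of piperidin-1-yl gives a 2.0-fold lower number from compound 1 to compound 3 (0.30 log units; within the scatter). Within the data shown here, the earlier step concerned only two rings with a single hetero atom, whereas these steps show that a six-membered ring with 2 hetero atoms, bearing a methyl group, also stands together with both of them, so no separation among the three rings can be read at this position. Nothing at hand accounts for this result in terms of the groups involved.

All three groups are saturated rings joined to the aromatic carbon through a ring nitrogen, so the series does not yet show whether an open-chain dimethylamino group or a carboxylic acid at this position would stay within the scatter of these compounds. Also open, on these data alone, is whether morpholin-4-yl, or a piperazin-1-yl ring without the methyl group, would stand with them.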